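Triphenylpyridine triols: moving hydroxyl positions, cytotoxicity

A few compounds are considered here, and "the series" means these few. Any claim that something is new, unique, unknown or untested is made for them only; others in the source may bear on it.

Compound 1 `Oc1ccc(-c2cc(-c3ccccc3O)cc(-c3cccc(O)c3)n2)cc1`: 5650 nM
Compound 2 `Oc1ccc(-c2cc(-c3ccc(O)cc3)nc(-c3cccc(O)c3)c2)cc1`: 840 nM
Compound 3 `Oc1ccc(-c2cc(-c3ccc(O)cc3)nc(-c3ccccc3O)c2)cc1`: not yet measured

In an ADME assay on HEK293 cells (Homo sapiens) for cytotoxicity, read by CCK-8 assay, with a stated time of 4 days (a higher number here means a weaker inhibitor, a lower number a stronger inhibitor), compound 2 gives the lowest of the two numbers; compound 1 sits above it, by a 6.7-fold lower number from compound 1 to compound 2 (0.83 log units; beyond the scatter). Compound 3 differs from compound 2 by 2-hydroxyphenyl in place of 3-hydroxyphenyl on an aromatic carbon. Among the measured compounds shown here, no measured step reproduces this exchange directly; the only one that touches it, a 6.7-fold lower number from compound 1 to compound 2 (0.83 log units; beyond the scatter), removed a 2-hydroxyphenyl and lowered the number, so bringing a 2-hydroxyphenyl back is expected to raise it. For compound 3 in this assay the estimate is 2500 nM, within 800 nM to 7000 nM, an expected step of a 3.0-fold higher number from compound 2 to compound 3 (0.47 log units; beyond the scatter).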

Compound 3, half-maximal inhibitory concentration: 26300 nM
Compound 3: middle estimate off by 11-fold (1.02 log units), on the low side, and the stated range ends below it.
By their numbers in this assay, from the lowest: compound 2; then compound 1; then compound 3.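

In this assay, the aromatic carbon next to the ring nitrogen proves highly sensitive to where the hydroxyl sits on its phenyl group. With the same atoms throughout, 2-hydroxyphenyl in place of 3-hydroxyphenyl gives a 31-fold higher number from compound 2 to compound 3 (1.50 log units; beyond the scatter), so the earlier step at another place on the shared core did not define the effect here. Nothing available explains this shift.

Still open, from the compounds shown here alone, is how 4-hydroxyphenyl at this carbon would compare. Also open, going by these compounds, is whether an amine or carboxylic acid on this phenyl group would keep the number near that of compound 2.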